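The source may report more compounds than this note shows. Statements on the series, on what has been measured and on what is new or still open speak of the compounds shown alone.

The measured compounds in an assay on cells for displacement of a labelled ligand from prostaglandin E2 receptor EP4 subtype (Homo sapiens), read by scintillation counting; a lower number here means a stronger inhibitor, a higher number a weaker inhibitor:

compound 1, `Cc1oc(C(=O)O)cc1COc1ccc(-c2ccc(Cl)cc2)cc1`, gives 1000 nM.
compound 2, `COc1ccccc1-c1ccc(OCc2cc(C(=O)O)oc2C)cc1`, gives 1600 nM.
compound 3, `Cc1oc(C(=O)O)cc1COc1ccc(-c2nnco2)cc1`, gives only a limit of the assay, > 10000 nM.

Compound 1 stands at the lowest of the two numbers shown in this assay, with compound 2 nearest to it; the difference a 1.6-fold higher number from compound 1 to compound 2 (0.20 log units; within the scatter) lies within the scatter. The value of compound 3 is a limit and not a number (the limit of > 10000 nM in this assay, at which 1 of the 3 values shown sits).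

The unmeasured compound 4, `Cc1oc(C(=O)O)cc1COc1ccc(-c2ccc(OC(F)(F)F)cc2)cc1`, differs from compound 1 in one place: trifluoromethoxy in place of chloro on an aromatic carbon. Within the data shown here, the aryl group on the shared core stays in place and only its substituent changes, so the step that bears most on it is the one from compound 1 to compound 2, where a different substituted phenyl gave a difference within the scatter, a 1.6-fold higher number from compound 1 to compound 2 (0.20 log units; within the scatter). The larger steps of an at least 10-fold higher number from compound 1 to compound 3 (1.00 log units; beyond the scatter) and an at least 6.2-fold higher number from compound 2 to compound 3 (0.79 log units; beyond the scatter) concern the loss of the phenyl ring altogether and do not apply here. Compound 4 is therefore expected to sit close to compound 1 in this assay, with the step of no change at the digits printed from compound 1 to compound 4 (within the scatter) expected to be within the scatter. The estimate for compound 4 is 1000 nM, between 400 nM and 2500 nM.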

Compound 4, inhibition constant: 2400 nM
Compound 4: middle estimate off by 2.4-fold (0.38 log units), on the low side; the measured number falls inside the stated range.
By their numbers in this assay, from the lowest: compounds 1, 2 and 4 (each within the scatter of the next, the first and the last beyond it). At a limit, above all of these: compound 3.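

In this assay, the change from chloro to trifluoromethoxy gives a 2.4-fold higher number from compound 1 to compound 4 (0.38 log units; beyond the scatter), and this is the first step shown that keeps the phenyl ring in place and alters only the group on it, on an aromatic carbon para to a large group. The number at this place therefore responds to the substituent alone, though the step remains modest, whereas replacing the whole 4-chlorophenyl with 1,3,4-oxadiazol-2-yl gives an at least 10-fold higher number from compound 1 to compound 3 (1.00 log units; beyond the scatter). Nothing measured here bears on what lies behind the step from chloro to trifluoromethoxy.

Only chloro and trifluoromethoxy are shown at this place on the phenyl ring, so it stays open how a methyl, a nitrile or an amine there would read in this assay, and whether any group at this place could bring the number below that of compound 1. Also open is how the shared core would read with an amide or a tetrazole in place of its carboxylic acid, which all the compounds shown carry.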